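The source may report more compounds than this note shows. Statements on the series, on what has been measured and on what is new or still open speak of the compounds shown alone.

Cytotoxicity across the series is read in an ADME assay on Huh-7 cells (Homo sapiens) for cytotoxicity, read by MTT assay, with a stated time of 48 h; a lower number here means that less compound is tolerated, a higher number that more compound is tolerated. Of the compounds shown here, two have numbers so far. Compound 1 `CN(C)CCCCN(C(=O)O)c1ccc(Cn2nc(-c3ccc(F)cc3)c3ccccc3c2=O)cc1` gives 19000 nM in this assay. Compound 2 `CN(C)CCCCOC(=O)Nc1ccc(Cn2nc(-c3ccncc3)c3ccccc3c2=O)cc1` gives 62700 nM in this assay, the highest of the two numbers; its nearest neighbour is compound 1, whose number is lower by a margin beyond the scatter. Among the measured compounds shown here, no step between compounds differing in one place has been measured, and compound 1 and compound 2 differ in more than one place, so the pair shows only that compound 2 is tolerated at the higher concentration.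

Compound 3 `CN(C)CCCCOC(=O)Nc1ccc(Cn2nc(-c3ccccc3)c3ccccc3c2=O)cc1` remains to be measured in this assay. It differs from compound 2 in one place: phenyl in place of pyridin-4-yl on an aromatic carbon. For the measured compounds named here, no measured step of this kind exists. Going by the values given here, the one compound that already carries a phenyl on the core, compound 1, gives 19000 nM, which points toward a somewhat lower number rather than a higher one. The step from compound 2 to compound 3 is therefore expected to be modest, a 1.6-fold lower number from compound 2 to compound 3 (0.20 log units; within the scatter), toward a lower number. For compound 3 the estimate is 40000 nM, with a range from 15000 nM to 100000 nM.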

Compound 3, half-maximal cytotoxic concentration: 16000 nM
Estimate against measurement, compound 3: 2.5-fold (0.40 log units) above; the measured number falls inside the stated range.
By their numbers in this assay, from the lowest: compounds 3 and 1 (each within the scatter of the next); then compound 2.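

Phenyl in place of pyridin-4-yl, on the aromatic carbon next to the ring nitrogen of the shared core, gives a 3.9-fold lower number from compound 2 to compound 3 (0.59 log units; beyond the scatter) in this assay and provides the first one-place step in the series. This position therefore responds to a single change within the attached six-membered aromatic ring: the heavy-atom count and the absence of net charge stay the same, while one ring nitrogen and its hydrogen-bond acceptor give way to carbon, and the step lies beyond the scatter. Among the compounds shown here, no measurement accompanies this step that would connect the shift in tolerated concentration to any particular feature of either ring.

The compounds shown leave open whether the higher number depends on the nitrogen of pyridin-4-yl specifically, which pyridin-3-yl or pyridin-2-yl at the same carbon would test. For the compounds shown here, they also leave open how a methoxy, an amine or a carboxylic acid on the phenyl of compound 3 would move the number in this cell assay, and whether the step holds with a shorter or longer chain in place of the one carried by compound 2 and compound 3.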